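Fluoro for methyl on the pendant aryl ring

The source may report more compounds than this note shows. Statements on the series, on what has been measured and on what is new or still open speak of the compounds shown alone.

Three members of the series have been measured in a functional assay on SK-OV-3 cells (Homo sapiens) for cytotoxicity; on this read-out higher numbers stand for weaker inhibition of growth and lower numbers for stronger inhibition of growth. Compound 1 `CSc1ccc(C2=C(c3ccc(F)c(F)c3)C(=O)N3CCCC3C2)cc1` gives 100 nM. Compound 2 `CSc1ccc(C2=C(c3ccc(F)c(C)c3)C(=O)N3CCCC3C2)cc1` gives 300 nM. Compound 3 `CSc1ccc(C2=C(c3ccc(C)cc3)C(=O)N3CCCC3C2)cc1` gives 9000 nM and stands as the weakest of the three, since its steps to both others lie beyond the scatter: a 90-fold higher number from compound 1 to compound 3 (1.95 log units; beyond the scatter) and a 30-fold higher number from compound 2 to compound 3 (1.48 log units; beyond the scatter). The difference between compound 2 and compound 3 is 4-methylphenyl in place of 4-fluoro-3-methylphenyl on a double-bonded ring carbon.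

Compound 4 `CSc1ccc(C2=C(c3ccc(F)cc3)C(=O)N3CCCC3C2)cc1` is not yet measured. It differs from compound 3 by fluoro in place of methyl on an aromatic carbon. The same kind of change is seen between compound 2 and compound 1, where fluoro in place of methyl on an aromatic carbon gave a 3.0-fold lower number from compound 2 to compound 1 (0.48 log units; beyond the scatter). The surroundings are not identical: in the measured pair the position is ortho to a fluoro group and meta to a large group, whereas in compound 4 it is para to a large group.

For compound 4 a larger step than the measured one is expected, a 9.0-fold lower number from compound 3 to compound 4 (0.95 log units; beyond the scatter), because compound 1 at 100 nM and compound 2 at 300 nM both carry fluoro at the position in question and both sit far below compound 3 at 9000 nM. Going by the values given here, the expected value for compound 4 in this assay is 1000 nM, within 200 nM to 5000 nM, with the exact size uncertain because only one fluoro-for-methyl step, a 3.0-fold lower number from compound 2 to compound 1 (0.48 log units; beyond the scatter), is available as a guide.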

Compound 4, concentration for 50% growth inhibition: 30000 nM
Beside the measured number, compound 4's estimate is 30-fold (1.48 log units) below it; measured number above the stated range.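

In this assay, fluoro in place of methyl on an aromatic carbon does not carry from one core to another with its direction kept: on the core of compound 3, the change gives a 3.3-fold higher number from compound 3 to compound 4 (0.52 log units; beyond the scatter), opposite in direction to the earlier step, and the two steps differ: the same change on two cores in this assay, a 3.0-fold lower number (0.48 log units; beyond the scatter) from compound 2 to compound 1 and a 3.3-fold higher number (0.52 log units; beyond the scatter) from compound 3 to compound 4, 10-fold (1.00 log units) apart, beyond the scatter of two such steps

The largest steps to compound 4 come from losing the second group on the ring, with hydrogen in place of methyl giving a 100-fold higher number from compound 2 to compound 4 (2.00 log units; beyond the scatter) and hydrogen in place of fluoro giving a 300-fold higher number from compound 1 to compound 4 (2.48 log units; beyond the scatter), so that in these two pairs the group on that carbon matters more than the fluoro-for-methyl change does in either pair. Going by these compounds alone, this shows only that the step measured on one core was a poor guide on the other; with two pairs, it does not show why the direction reverses, nor which direction would hold on a further core.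

Going by these compounds, it remains open whether chloro, methoxy or a nitrile on the carbon that changes between compound 3 and compound 4 would follow compound 3, compound 4 or neither. Also open, on these data alone, is whether ethyl, trifluoromethyl or an amine in place of the methyl of compound 2 would keep numbers near those of compound 1 and compound 2.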